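This account rests on a few compounds, and the source may have more. Where it says the series, first, only, none or still open, it means among the compounds named here.

In a functional assay on ACHN cells (Homo sapiens) (on this read-out higher numbers stand for weaker inhibition of growth and lower numbers for stronger inhibition of growth), compound 1 `O=S(=O)(/C=C/c1ccc(Cl)cc1)Cc1ccc(Nc2ncnc3ccccc23)cc1` gives > 100000 nM, which is a limit of the assay and not a number. For the measured compounds named here, compound 2 `O=S(=O)(/C=C/c1ccc(C(F)(F)F)cc1F)Cc1ccc(Nc2ncnc3ccccc23)cc1` gives 100000 nM, the only actual number so far. Going by the values given here, the one measured step is a number no higher from compound 1 to compound 2 (the limit leaves the size open), and its size cannot be read. Compound 3 `O=S(=O)(/C=C/c1ccc(O)cc1)Cc1ccc(Nc2ncnc3ccccc23)cc1` brings a further change at the same place, on a double-bonded chain carbon bound to a double-bonded chain carbon: 4-hydroxyphenyl in place of 2-fluoro-4-(trifluoromethyl)phenyl on a double-bonded chain carbon bound to a double-bonded chain carbon. The group that enters is 4-hydroxyphenyl, and the group that leaves is 2-fluoro-4-(trifluoromethyl)phenyl. With no measured size to carry over, no step beyond the scatter can be argued for in either direction in this assay, so little change from compound 2 at 100000 nM is expected. The expected step is a 1.4-fold lower number from compound 2 to compound 3 (0.15 log units; within the scatter). For compound 3 the estimated value is 70000 nM, with an expected range of 20000 nM to 100000 nM.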

Compound 3, concentration for 50% growth inhibition: 20 nM
Compound 3: middle estimate off by 3500-fold (3.54 log units), on the high side; measured number below the stated range.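

In this assay there is a 5000-fold lower number from compound 2 to compound 3 (3.70 log units; beyond the scatter) when 4-hydroxyphenyl replaces 2-fluoro-4-(trifluoromethyl)phenyl, so the group on a double-bonded chain carbon bound to a double-bonded chain carbon can decide between almost no inhibition of growth and strong inhibition. A single exchange on the ring, hydroxy in place of chloro on an aromatic carbon, already gives an at least 5000-fold lower number from compound 1 to compound 3 (3.69 log units; beyond the scatter) and so the whole gain needs no larger change than that. The entering group counts a hydrogen-bond donor and the leaving groups none, although this is only a structural difference and not a shown cause, and the second step has a lower bound for its size: the limit of > 100000 nM in this assay, at which 1 of the 3 values shown sits.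

A 4-methoxyphenyl or a 4-aminophenyl group at this place would test whether the hydroxy group itself is what counts. From the compounds shown here alone, how compound 3 behaves on other cell lines also stays open.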